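Swapping chloro for furan-2-yl in an anticonvulsant series

This account rests on a few compounds, and the source may have more. Where it says the series, first, only, none or still open, it means among the compounds named here.

Compound 1 `SC1=NC(n2nc(-c3ccccc3)nc2-c2ccccc2)=CC(c2ccc(Cl)cc2)N1` was tested in a functional assay on the whole organism with Mus musculus as the target, in the maximal electroshock model, with a stated time of 0.5 h (on this read-out higher numbers stand for an effect only at larger amounts of compound and lower numbers for an effect already at smaller amounts), and gives 30 mg/kg. Compound 2 `O=[N+]([O-])c1cccc(C2C=C(n3cc(-c4ccccc4)nc3-c3ccccc3)N=C(S)N2)c1` gives 30 mg/kg, so in this assay compound 1 stands level with compound 2 at the digits shown, within the scatter. Compound 3 `SC1=NC(n2nc(-c3ccccc3)nc2-c2ccccc2)=CC(c2ccc(-c3ccco3)cc2)N1` has not yet been measured. It differs from compound 1 by furan-2-yl in place of chloro on an aromatic carbon. For the measured compounds named here, no measured pair shows this kind of change, so the step from compound 1 to compound 3 is expected to be small in this assay, with no clear direction: no change at the digits printed from compound 1 to compound 3 (within the scatter). Compound 3 is therefore estimated at 30 mg/kg, with a range from 10 mg/kg to 100 mg/kg.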

Compound 3, minimum effective dose: 30 mg/kg
Compound 3: the middle estimate sits on the measured number at the digits printed, within the range that was stated.
By their numbers in this assay, from the lowest: compounds 1, 2 and 3 (each within the scatter of the next).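

In this assay, putting furan-2-yl in place of chloro gives no change at the digits printed from compound 1 to compound 3 (within the scatter). For the compounds shown here, this is the first direct reading at this position: on the six-membered aromatic ring, para to a large group, a single chlorine atom can give way to a whole five-membered aromatic ring without a change beyond the scatter. No supporting measurement accounts for this result.

Going by these compounds, whether an amine or a carboxylic acid at the same position would also leave the minimum effective dose level remains open. Compound 2 differs from compound 1 in more than one place, so it cannot settle this.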